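Adding a methyl group to compound 2

The source may hold more compounds than are shown below. What is called first, only, known or untested is meant among the compounds shown, and "the series" means these compounds.

Measured so far in a functional assay on SK-MEL-28 cells (Homo sapiens) for cytotoxicity; on this read-out higher numbers stand for weaker inhibition and lower numbers for stronger inhibition:
compound 1 `CC(C)=CCCC1=CCc2c(O)ccc(O)c2C1` gives 4900 nM
compound 2 `CC(=O)Oc1ccc(OC(C)=O)c2c1CC=C(CCC=C(C)C)C2` gives 3600 nM
compound 3 `CC(C)=CCCC1=CCc2c(O)cc(C)c(O)c2C1` gives 19400 nM

Among these three, compound 2 at 3600 nM has the lowest number, but it cannot be separated from compound 1. The two values lie within the scatter of each other. Compound 3 stands beyond the scatter from compound 2, with the higher number.

Compound 4 `CC(=O)Oc1cc(C)c(OC(C)=O)c2c1CC=C(CCC=C(C)C)C2` has not yet been measured. It differs from compound 2 by a single change, methyl in place of hydrogen on an aromatic carbon described as methyl in place of hydrogen on an aromatic carbon, ortho to an acetoxy group.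

Going by the values given here, only one measured step bears on this change. The same replacement gives a 4.0-fold higher number from compound 1 to compound 3 (0.60 log units; beyond the scatter) and that step is modest but beyond the scatter. Among the compounds with values here, it was seen in compounds without the acetoxy groups, and no measured pair shows the change among compounds that carry them, so only part of its size is carried over. An estimated 3.1-fold higher number from compound 2 to compound 4 (0.49 log units; beyond the scatter) is therefore expected in this assay as a move towards weaker inhibition. Compound 4 is expected at about 11000 nM within a range of 4500 nM to 25000 nM on this estimate.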

Compound 4, half-maximal inhibitory concentration: 14600 nM
For compound 4 the middle estimate is 1.3-fold (0.12 log units) below the measured one; the range from low to high includes it.
By their numbers in this assay, from the lowest: compounds 2 and 1 (each within the scatter of the next); then compounds 4 and 3 (each within the scatter of the next).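

In this assay, methyl in place of hydrogen on the aromatic carbon ortho to an acetoxy group gives a 4.1-fold higher number from compound 2 to compound 4 (0.61 log units; beyond the scatter), so the move towards weaker inhibition also appears among compounds that carry the acetoxy groups. The earlier compounds shown here showed this change on one core only, and it now stands on two with almost the same size: the same change on two cores in this assay, a 4.0-fold higher number (0.60 log units; beyond the scatter) from compound 1 to compound 3 and a 4.1-fold higher number (0.61 log units; beyond the scatter) from compound 2 to compound 4, 1.0-fold (0.01 log units) apart, within the scatter of two such steps. Across these two pairs, the size of the step at this position therefore did not depend on whether the core carried acetoxy groups, which the single earlier pair could not show.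

All the compounds shown hold either hydrogen or methyl at this position, so it remains open whether an ethyl group, a methoxy group or a chlorine atom there would move the number in the same direction and by a similar step. They also share one side chain, which leaves open whether the step would hold on a core with a shorter chain in its place or with a carboxylic acid at the end of that chain.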